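The source may hold more compounds than are shown below. What is called first, only, known or untested is meant among the compounds shown, and "the series" means these compounds.

Among the measured compounds shown here, compound 2 `NC(=O)c1c(NC(=O)c2ccccc2Cl)sc2c1CCN(C(=S)Nc1ccccc1I)C2` gives 4430 nM in a functional assay on HL-60 cells (Homo sapiens) for antiproliferative activity, with a stated time of 24 h (on this read-out higher numbers stand for weaker inhibition and lower numbers for stronger inhibition), the lower of the two numbers measured so far; compound 1 `NC(=O)c1c(NC(=O)c2ccccc2Cl)sc2c1CCN(Cc1ccc(Cl)cc1)C2` gives 22500 nM in this assay. For the measured compounds named here, the single measured step, a 5.1-fold lower number from compound 1 to compound 2 (0.71 log units; beyond the scatter), changed the group on the amine nitrogen in the ring, not the part altered here. Compound 3 `NC(=O)c1c(NC(=O)c2ccccc2Cl)sc2c1CCN(C(=S)Nc1ccc(C(F)(F)F)cc1)C2` differs from compound 2 as follows: 4-(trifluoromethyl)phenyl in place of 2-iodophenyl on an amide-type nitrogen. Going by the values given here, no measured step bears on this swap of one aromatic ring for another, so the expected step is a 1.1-fold higher number from compound 2 to compound 3 (0.05 log units; within the scatter), within the scatter. For compound 3 the estimate in this assay is 5000 nM, with a range from 1500 nM to 16000 nM.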

Compound 3, half-maximal inhibitory concentration: 7590 nM
Beside the measured number, compound 3's estimate is 1.5-fold (0.18 log units) below it; the measured number falls inside the stated range.
By their numbers in this assay, from the lowest: compounds 2 and 3 (each within the scatter of the next); then compound 1.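

In this assay the swap on the amide-type nitrogen gives a 1.7-fold higher number from compound 2 to compound 3 (0.23 log units; within the scatter) and so stays within the usual scatter. With the thiocarbonyl kept, this position accepts either 2-iodophenyl or 4-(trifluoromethyl)phenyl with no difference that can be read, even though the two rings carry different groups. No measurement at hand explains this result.

The two aryl groups differ in both substituent and its place, so those two changes cannot be separated. On these data alone, whether a non-aromatic group such as cyclohexyl or a short alkyl chain would fit here also remains open.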